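The compounds below may be only part of what the source reports. "The series", "measured", "known", "first", "only" and "open" are said of these compounds alone.

In a functional assay on MCF7 cells (Homo sapiens) for antiproliferative activity, read by MTT assay, with a stated time of 72 h (on this read-out lower numbers stand for stronger inhibition and higher numbers for weaker inhibition), three compounds on one shared core have been measured. Compound 3 (`CCCSc1nc(N/N=C/c2ccccc2)c2nnn(Cc3ccccc3)c2n1`) gives only a limit, > 64000 nM. Compound 1 (`CCCSc1nc(N/N=C(\C)c2ccc(OC)cc2)c2nnn(Cc3ccccc3)c2n1`) also gives only a limit, > 64000 nM. Among the measured compounds shown here, compound 2 (`CCCSc1nc(N/N=C(\C)c2ccccc2)c2nnn(Cc3ccccc3)c2n1`) gives the only true number, 32100 nM. Compound 3 therefore stands with compound 1 at the limit of > 64000 nM in this assay, at which 2 of the 3 values shown sit.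

The next compound is compound 4 (`CCCSc1nc(N/N=C(\C)c2ccc(Br)cc2)c2nnn(Cc3ccccc3)c2n1`), and the change is a group of 10 heavy atoms (8 carbon, 1 nitrogen, 1 bromine; one six-membered aromatic ring of carbon only) in place of a group of 8 heavy atoms (7 carbon, 1 nitrogen; one six-membered aromatic ring of carbon only), on a nitrogen on an aromatic ring. The group that enters keeps the one six-membered aromatic ring of carbon only and the 1 double bond outside aromatic rings, and it brings 1 bromine.

For the measured compounds named here, two measured steps bear on this change. The closer one is an at least 1.9-fold higher number from compound 2 to compound 3 (0.29 log units; that floor lies within the scatter), an exchange on the same nitrogen. The other, an at least 1.9-fold lower number from compound 1 to compound 2 (0.29 log units; that floor lies within the scatter), is a change on an aromatic carbon, with hydrogen in place of methoxy. Each is known only as a floor, so neither fixes a size.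

Compound 4 shares more of its group with compound 2, at 32100 nM, than with compound 3, so a modest move toward a lower number is expected. A reading at the limit also remains possible for compound 4. The expected change is an at least 2.1-fold lower number from compound 3 to compound 4 (0.32 log units; beyond the scatter). For compound 4 the estimate is 30000 nM, with an expected range from 10000 nM to 64000 nM.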

Compound 4, half-maximal inhibitory concentration: 13000 nM
Beside the measured number, compound 4's estimate is 2.3-fold (0.36 log units) above it; the measured number falls inside the stated range.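

In this assay, among the compounds shown here, bromo in place of hydrogen on an aromatic carbon gives the first step between two true numbers, and it lies beyond the scatter: a 2.5-fold lower number from compound 2 to compound 4 (0.39 log units; beyond the scatter). Bromo in place of methoxy at that carbon gives an at least 4.9-fold lower number from compound 1 to compound 4 (0.69 log units; beyond the scatter), and the whole exchange on the nitrogen gives an at least 4.9-fold lower number from compound 3 to compound 4 (0.69 log units; beyond the scatter), so both floors now lie beyond the scatter, whereas the floors of the earlier steps lay within it. These two steps remain floors and do not fix a size, since compound 1 and compound 3 each give only a limit: the limit of > 64000 nM in this assay, at which 2 of the 4 values shown sit.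

The compounds shown leave open whether chloro, fluoro or a nitrile on the same aromatic carbon would give a number like that of compound 4, or whether an amine or a carboxylic acid there would move it the other way. They also leave open whether bromo would lower the number in a group without the methyl that compound 3 lacks, and how the propylthio chain and the benzyl group on the shared core contribute.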